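Stability of three stereoisomers and a fourth to come

The compounds below may be only part of what the source reports. "The series", "measured", "known", "first", "only" and "open" are said of these compounds alone.

Measured so far in a physicochemical assay for metabolic stability, read by HPLC, in phosphate buffer, with a stated time of 12 h, at pH 7.2; a lower number here means that the compound disappears faster, a higher number that the compound lasts longer:
- compound 1 `O=C(N[C@H](CO)C(=O)O)[C@@H]1C[C@@H](O)CN1`, compound 1 gives > 12 h, a limit of the assay
- compound 2 `O=C(N[C@H](CO)C(=O)O)[C@@H]1C[C@H](O)CN1`, compound 2 gives > 12 h, a limit of the assay
- compound 3 `O=C(O)[C@H](CO)NC(=O)[C@@H]1C[C@@H](O)CN1`, compound 3 gives > 12 h, a limit of the assay

Compound 1 stands at the limit of this assay, and no number is known for it. The same holds for compound 2 and for compound 3, so all three values sit at one limit (the limit of > 12 h in this assay, at which 3 of the 3 values shown sit). The steps among them are therefore unreadable: a step that the two limits leave unreadable from compound 1 to compound 2, a step that the two limits leave unreadable from compound 1 to compound 3 and a step that the two limits leave unreadable from compound 2 to compound 3. Each of these pairs differs only in configuration as drawn the fact that compounds 1 and 2 differ only in the configuration as drawn the fact that compounds 1 and 3 differ only in the configuration as drawn (the fact that compounds 2 and 3 differ only in the configuration as drawn).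

Compound 4 `O=C(O)[C@@H](CO)NC(=O)[C@H]1C[C@@H](O)CN1` is not yet measured. Its difference from compound 1: the two compounds have the same atoms and bonds and differ only in configuration as drawn: 1 of 3 stereo elements differ; a stereocentre at a saturated ring carbon is drawn S in compound 1 and R in compound 4. The step that bears on it most closely is the other change at a saturated ring carbon, a step that the two limits leave unreadable from compound 1 to compound 2, which gave no readable size; the change at the saturated chain carbon, a step that the two limits leave unreadable from compound 1 to compound 3, is likewise unreadable. No stereochemical change in this set has moved a compound off the limit.

Compound 4 is therefore expected to stay at the limit of this assay as well, with an estimated half-life of 24 h (range 12 h to 60 h). The expected step from compound 1 is a step that the limit leaves unreadable from compound 1 to compound 4, that is no readable change beyond the scatter.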

Compound 4, half-life: > 12 h
Compound 4: a limit, no number; the forecaster's own chance of this, stated with the estimate: 90%; the middle value does not contradict the limit.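

In this assay compound 4 gives > 12 h, a limit and not a number. No new step can be read between compound 4 and compounds 1, 2 or 3, as all four compounds sit at one limit: the limit of > 12 h in this assay, at which 4 of the 4 values shown sit.

The compounds shown leave open how long each one actually lasts and whether configuration changes the half-life at all.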